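The source may hold more compounds than are shown below. What is called first, only, known or untested is meant among the compounds shown, and "the series" means these compounds.

Of the compounds shown here, three built on one shared core have so far been measured in an ADME assay on PC-3 cells (Homo sapiens) for cytotoxicity, read by WST assay, tested at 100 uM; on this read-out lower numbers stand for less inhibition and higher numbers for more inhibition at the one concentration tested (going by the name of the read-out). Compound 1 `COC(=O)c1cccc(C(=O)N2CCCC(C(=O)Nc3ccc(Cl)cc3)C2)c1` gives 0%. Compound 2 `Cc1nc(-c2cccc(C(=O)N3CCCC(C(=O)Nc4ccc(Cl)cc4)C3)c2)cs1` gives 1%. Compound 3 `O=C(Nc1ccc(Cl)cc1)C1CCCN(C(=O)c2cccc([N+](=O)[O-])c2)C1` gives 0%, level with compound 1 at the digits shown and together with it the lowest of the three numbers. The two exchanges at the same aromatic carbon that lead to compound 3 were no change at the digits printed from compound 1 to compound 3 (within the scatter) and a number 1 percentage points lower from compound 2 to compound 3 (within the scatter), both within the scatter. Compound 4 `CC(C)(C)CC(=O)Nc1cccc(C(=O)N2CCCC(C(=O)Nc3ccc(Cl)cc3)C2)c1` differs from compound 3 by (neopentylcarbonyl)amino in place of nitro on an aromatic carbon. Because the earlier exchanges at this carbon gave no change at the digits printed from compound 1 to compound 3 (within the scatter) and a number 1 percentage points lower from compound 2 to compound 3 (within the scatter), the expected step is a number 2 percentage points higher from compound 3 to compound 4 (within the scatter), that is none beyond the scatter. Compound 4 is therefore estimated at 2%, with a range from 0% to 12%.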

Compound 4, a percentage reported as inhibition, at one concentration (the size of the read-out at that concentration, not a potency): 0%
For compound 4 the middle estimate is 2 percentage points above the measured one; measured number inside the range.
By their numbers in this assay, from the lowest: compounds 1, 3, 4 and 2 (each within the scatter of the next).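

In this assay, the exchange at this aromatic carbon now extends to a larger group that brings a hydrogen-bond donor: (neopentylcarbonyl)amino, with 8 heavy atoms against 3 for nitro, gives no change at the digits printed from compound 3 to compound 4 (within the scatter). Set against the other two groups, it gives no change at the digits printed from compound 1 to compound 4 (within the scatter) and a number 1 percentage points lower from compound 2 to compound 4 (within the scatter), so all four groups at this carbon now lie within the scatter of one another. Nothing available bears on why this is so.

On these data alone, whether an amine or a carboxylic acid at this carbon would move the number beyond the scatter remains open. So does the effect of any exchange elsewhere on the shared core.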